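Swapping Methyl for Methoxy on an Aromatic Carbon

The source may report more compounds than this note shows. Statements on the series, on what has been measured and on what is new or still open speak of the compounds shown alone.

In a functional assay on CCRF-CEM cells (Homo sapiens) for inhibition (on this read-out higher numbers stand for weaker inhibition and lower numbers for stronger inhibition), compound 1 `O=C1/C(=C/c2cccc(Cl)c2)Cc2ccccc21` gives 31800 nM. Compound 2 `Cc1cccc(/C=C2\Cc3ccccc3C2=O)c1`, which carries methyl in place of chloro on an aromatic carbon, gives 41300 nM. The measured step is a 1.3-fold higher number from compound 1 to compound 2 (0.11 log units; within the scatter), so compound 2 stands level with compound 1, and there is no other number to compare it with.

Compound 3 `COc1cccc(/C=C2\Cc3ccccc3C2=O)c1` differs from compound 2 by one change: methoxy in place of methyl on an aromatic carbon. Going by the values given here, no methoxy compound has been measured yet, so the only guide is a different swap on an aromatic carbon, a 1.3-fold higher number from compound 1 to compound 2 (0.11 log units; within the scatter). That small step gives no reason to expect a shift beyond the scatter in this assay, in either direction. The estimated step is a 1.1-fold lower number from compound 2 to compound 3 (0.06 log units; within the scatter), which is no real change. For compound 3 the expected value is 36000 nM, with an estimated range from 16000 nM to 80000 nM.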

Compound 3, half-maximal inhibitory concentration: > 500000 nM
Compound 3 gave a limit, no number; the forecaster's own chance of this, stated with the estimate: 10%; middle value at least 13-fold (1.14 log units) from the limit.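

The earlier step between chloro and methyl stayed within the scatter, so this position seemed to tolerate a swap, but methoxy behaves differently in this assay. The change from methyl to methoxy gives an at least 12-fold higher number from compound 2 to compound 3 (1.08 log units; beyond the scatter), and the change from chloro to methoxy gives an at least 15-fold higher number from compound 1 to compound 3 (1.19 log units; beyond the scatter), so inhibition is largely lost with this one group on this aromatic carbon, meta to a large group. Compound 3 gives no exact number here, only a limit of the assay: the limit of > 500000 nM in this assay, at which 1 of the 3 values shown sits.

The compounds shown leave open whether the loss follows the oxygen of the methoxy, which brings a hydrogen-bond acceptor that methyl lacks, or simply the extra heavy atom. A hydroxyl or an ethyl on the same aromatic carbon would help to tell these two readings apart.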